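Fluoro in place of hydrogen on the fused core: toxicity outlook

The source may report more compounds than this note shows. Statements on the series, on what has been measured and on what is new or still open speak of the compounds shown alone.

Two compounds of this series have been run in an ADME assay on MT2 cells (Homo sapiens) for cytotoxicity, read by MTT assay; on this read-out lower numbers stand for higher toxicity in this test and higher numbers for lower toxicity in this test. Compound 1 `O=c1ccn(CCOc2ccccc2Oc2cccc3cc(Cl)ccc23)c(=O)[nH]1` reaches only the limit of the assay, > 100000 nM, and gives no number. Compound 2 `N#Cc1cc2c(Oc3ccccc3OCCn3ccc(=O)[nH]c3=O)cccn2c1` likewise stops at the limit, > 100000 nM, with no number beneath it. Compound 2 thus stands exactly where the other value of the set stands: the limit of > 100000 nM in this assay, at which 2 of the 2 values shown sit. The two cannot be ordered against each other; both only show that toxicity was not reached within the tested range.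

Compound 3 `N#Cc1cc2c(Oc3ccccc3OCCn3ccc(=O)[nH]c3=O)cc(F)cn2c1` has not yet been measured. It differs from compound 2 by fluoro in place of hydrogen on an aromatic carbon. Nothing measured in the series speaks to a fluoro at this place, and with both values resting at the limit, no step beyond the scatter in this assay can be read for either direction. The step expected is a number no higher from compound 2 to compound 3 (the limit leaves the size open), none beyond the scatter. Compound 3 is accordingly estimated at 100000 nM, with a range from 50000 nM to 200000 nM, most probably returned once more as a limit rather than a number.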

Compound 3, half-maximal cytotoxic concentration: 40000 nM
Compound 3: the middle estimate sits 2.5-fold (0.40 log units) above what was measured; the whole stated range lies above it.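

In this assay, this aromatic carbon, two atoms from the ring nitrogen, proves to be a place where a change of a single atom can register: fluoro in place of hydrogen gives an at least 2.5-fold lower number from compound 2 to compound 3 (0.39 log units; beyond the scatter). The lower number stands for higher toxicity in this test, and compound 3 is the only compound shown that has a number inside the tested range, so the series now has one measured toxicity signal, tied to this one change. The true size of the step stays open, since compound 2 gives only a limit: the limit of > 100000 nM in this assay, at which 2 of the 3 values shown sit.

The compounds shown leave open whether this step belongs to fluoro itself or would follow any group at this place, and chloro, methyl, methoxy or an amine on the same carbon would separate these two readings. Also open, on these data alone, is whether the step depends on the nitrile-bearing core of compound 2 or would recur with fluoro on the core of compound 1, so for now it holds for this single pair only.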